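A few compounds are considered here, and "the series" means these few. Any claim that something is new, unique, unknown or untested is made for them only; others in the source may bear on it.

Of the compounds shown here, three built on a shared core have been tested in a functional assay on NSCLC cells (Homo sapiens) for antiproliferative activity; a higher number here means a weaker inhibitor of growth, a lower number a stronger inhibitor of growth. Compound 1 `Cc1sc2nc(-c3ccncc3)c(/C=N/NC(=N)N)n2c1C` gives 97700 nM, compound 2 `Cc1cn2c(/C=N/NC(=N)N)c(-c3cccnc3)nc2s1` gives 36300 nM, and compound 3 `N=C(N)N/N=C/c1c(-c2ccccn2)nc2sc(Cl)cn12` gives 18600 nM. Compound 3 thus lies within the scatter of compound 2 and beyond the scatter on the stronger side of compound 1. Compound 4 `N=C(N)N/N=C/c1c(-c2cccnc2)nc2sc(Cl)cn12` differs from compound 3 in one place: pyridin-3-yl in place of pyridin-2-yl on an aromatic carbon, on an aromatic carbon of a five-membered aromatic ring with 2 nitrogen. Going by the values given here, no measured pair shows this change alone. Compound 2 also carries pyridin-3-yl and, at 36300 nM, lies within the scatter of compound 3, although it differs elsewhere too. The expected step, a 1.2-fold higher number from compound 3 to compound 4 (0.09 log units; within the scatter), is estimated to stay within the scatter. For compound 4 the expected value is 23000 nM, with an estimated range of 9000 nM to 60000 nM.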

Compound 4, concentration for total growth inhibition: 41700 nM
Compound 4: middle estimate off by 1.8-fold (0.26 log units), on the low side, and the stated range covers the measured number.
By their numbers in this assay, from the lowest: compounds 3, 2 and 4 (each within the scatter of the next, the first and the last beyond it); then compound 1.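

Pyridin-3-yl in place of pyridin-2-yl on an aromatic carbon gives a 2.2-fold higher number from compound 3 to compound 4 (0.35 log units; beyond the scatter) in this assay and is the first single change read at this position, showing that the pyridine's point of attachment has a modest bearing on the number. With pyridin-3-yl held, chloro in place of methyl on an aromatic carbon gives a 1.1-fold higher number from compound 2 to compound 4 (0.06 log units; within the scatter) and so leaves the number within the scatter. Nothing available accounts for the pyridine step. On these data alone, whether phenyl, or an amine on the pyridine, would keep or shift the number stays open. So does how pyridin-4-yl compares with chloro kept, since compound 1 differs elsewhere too.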